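Three limits reached, a fourth analogue awaiting measurement

This account rests on a few compounds, and the source may have more. Where it says the series, first, only, none or still open, it means among the compounds named here.

Compound 1 `COc1ccc(-n2c(SCC(=O)C3CC3)nnc2-c2cc(OC)c(OC)c(OC)c2)cc1`, compound 2 `CCOC(=O)CSc1nnc(-c2cc(OC)c(OC)c(OC)c2)n1-c1ccc(OC)cc1` and compound 3 `COc1cc(-c2nnc(SCC(=O)C3CC3)n2-c2ccc(N(C)C)cc2)cc(OC)c1OC` share one core. In a functional assay on HT-29 cells (Homo sapiens) for inhibition, read by MTT assay, with a stated time of 48 h (a lower number here means a stronger inhibitor, a higher number a weaker inhibitor), compound 1 reaches only the limit > 60000 nM. Compound 2 also gives only the limit > 60000 nM in this assay. Compound 3 likewise stops at the limit > 60000 nM in this assay. Compound 2 differs from compound 1 by ethoxy in place of cyclopropyl on a carbonyl carbon, a step that reads a step that the two limits leave unreadable from compound 1 to compound 2. Compound 3 differs from compound 1 by dimethylamino in place of methoxy on an aromatic carbon, a step that reads a step that the two limits leave unreadable from compound 1 to compound 3. Compound 4 `CCOC(=O)CSc1nnc(-c2cc(OC)c(OC)c(OC)c2)n1-c1ccc(N(C)C)cc1` is unmeasured and differs from compound 3 by ethoxy in place of cyclopropyl on a carbonyl carbon, the same change as between compound 1 and compound 2. Because (the limit of > 60000 nM in this assay, at which 3 of the 3 values shown sit), the step is expected to be a step that the limit leaves unreadable from compound 3 to compound 4 in this assay. Compound 4 is therefore expected to give about 80000 nM in this assay, most likely again only as a limit.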

Compound 4, half-maximal inhibitory concentration: 28800 nM
Beside the measured number, compound 4's estimate is 2.8-fold (0.44 log units) above it; the whole stated range lies above it.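

In this assay, ethoxy in place of cyclopropyl on a carbonyl carbon gives an at least 2.0-fold lower number from compound 3 to compound 4 (0.31 log units; beyond the scatter), and dimethylamino in place of methoxy on an aromatic carbon gives an at least 2.0-fold lower number from compound 2 to compound 4 (0.31 log units; beyond the scatter). The ethoxy change can thus be read on the core bearing dimethylamino, where compound 4 is the only compound shown with a number rather than a limit. The steps among compounds 1, 2 and 3 cannot be read, so this does not show that the ethoxy change carries from one core to another, or with what size: the limit of > 60000 nM in this assay, at which 3 of the 4 values shown sit.

As far as these compounds go, whether the ethoxy change lowers the number only alongside dimethylamino stays open. So does how a carboxylic acid or a longer ester chain in place of the ethoxy would read on this core.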